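Azide-terminated linker extensions on the shared pyrimidinone core

The compounds below may be only part of what the source reports. "The series", "measured", "known", "first", "only" and "open" are said of these compounds alone.

Measured compounds:
compound 1 `CCNC(=O)Nc1ccc(-c2nc3n(Cc4c(F)cccc4F)cc(C(=O)OCC)c(=O)n3c2CN(CC(=O)NCc2cn(CCOCCN=[N+]=[N-])nn2)Cc2ccccc2)cc1` gives 525 nM
compound 2 `CCNC(=O)Nc1ccc(-c2nc3n(Cc4c(F)cccc4F)cc(C(=O)OCC)c(=O)n3c2CN(CC(=O)NCc2cn(CCOCCOCCN=[N+]=[N-])nn2)Cc2ccccc2)cc1` gives 468 nM
compound 3 `CCNC(=O)Nc1ccc(-c2nc3n(Cc4c(F)cccc4F)cc(C(=O)NCc4cn(CCOCCOCCOCCN=[N+]=[N-])nn4)c(=O)n3c2CN(C)Cc2ccccc2)cc1` gives < 10000 nM

In a functional assay on CHO cells for antagonist activity at Gonadotropin-releasing hormone receptor (Homo sapiens), read by a luciferase reporter, with a stated time of 30 min (on this read-out lower numbers stand for stronger inhibition and higher numbers for weaker inhibition), compound 1 gives 525 nM and compound 2 gives 468 nM. The change between them is 2-azidoethoxy in place of azido on a saturated chain carbon, two bonds along the chain from an oxygen on a saturated carbon and the step is a 1.1-fold lower number from compound 1 to compound 2 (0.05 log units; within the scatter). The two values therefore cannot be told apart. For compound 3 the assay reports only a limit, < 10000 nM, and this value sits at the limit of < 10000 nM in this assay, at which 1 of the 3 values shown sits. The difference between the core of compound 1 and the core of compound 3 is not broken down here.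

Compound 4 `CCNC(=O)Nc1ccc(-c2nc3n(Cc4c(F)cccc4F)cc(C(=O)NCc4cn(CCOCCOCCOCCOCCN=[N+]=[N-])nn4)c(=O)n3c2CN(C)Cc2ccccc2)cc1` is not yet measured in this assay. It differs from compound 3 by 2-azidoethoxy in place of azido on a saturated chain carbon, two bonds along the chain from an oxygen on a saturated carbon, the same change that was made from compound 1 to compound 2. Because that earlier step read a 1.1-fold lower number from compound 1 to compound 2 (0.05 log units; within the scatter), the expected step from compound 3 to compound 4 is small, a step that the limit leaves unreadable from compound 3 to compound 4, and because compound 3 sits at the limit of < 10000 nM in this assay, at which 1 of the 3 values shown sits, the assay is expected to report a limit for compound 4 as well. The estimate for compound 4 is 4000 nM, with a range from 600 nM to 15000 nM.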

Compound 4, half-maximal inhibitory concentration: < 10000 nM
Compound 4: no number, only a limit; the forecaster's own chance of this, stated with the estimate: 60%; the middle value is on the limit's open side.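

Compound 3 and compound 4 both return only a limit in this assay, and no step between them can be read: the limit of < 10000 nM in this assay, at which 2 of the 4 values shown sit.

The compounds shown leave open where compound 3 and compound 4 actually lie, and whether 2-azidoethoxy in place of azido reads the same on the core of compound 3 as on the core of compound 1.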